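Replacing the hydroxyphenyl in compound 3 with dimethylaminophenyl

The source may report more compounds than this note shows. Statements on the series, on what has been measured and on what is new or still open speak of the compounds shown alone.

Three compounds sharing one core were tested in a functional assay, with a stated time of 20 min, tested at 20 uM; a higher number here means a stronger effect of the compound at the concentration tested, a lower number a weaker effect. Compound 1 `COc1cc(/C=C/C(=O)C2=C(/C=C/c3ccc(O)c(OC)c3)NC(=S)NC2c2ccccc2)ccc1O` gives 36.6% in this assay. Compound 2 `COc1cc(/C=C/C(=O)C2=C(/C=C/c3ccc(O)c(OC)c3)NC(=S)NC2c2ccc(C)cc2)ccc1O` gives 30%, and a number 6.6 percentage points lower from compound 1 to compound 2 (within the scatter). Compound 3 `COc1cc(/C=C/C(=O)C2=C(/C=C/c3ccc(O)c(OC)c3)NC(=S)NC2c2ccccc2O)ccc1O` gives 79.9%, the highest of the three numbers; its gaps to the others, a number 43.3 percentage points higher from compound 1 to compound 3 (beyond the scatter) and a number 49.9 percentage points higher from compound 2 to compound 3 (beyond the scatter), both lie beyond the scatter.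

Compound 4 `COc1cc(/C=C/C(=O)C2=C(/C=C/c3ccc(O)c(OC)c3)NC(=S)NC2c2ccc(N(C)C)cc2)ccc1O` has not yet been measured in this assay. The change from compound 3 is 4-(dimethylamino)phenyl in place of 2-hydroxyphenyl on a saturated ring carbon. Within the data shown here, two measured steps bear on it: the step from compound 1 to compound 3, where the hydroxy was added, and the step from compound 2 to compound 3, where a 4-methylphenyl was exchanged for the 2-hydroxyphenyl. Both were large, and in compound 4 the 2-hydroxyphenyl is lost again while a group on the far position of the ring, as in compound 2, is gained. Compound 4 is therefore expected to fall back, with a number 44.9 percentage points lower from compound 3 to compound 4 (beyond the scatter). Compound 4 is estimated at 35%, within a range from 15% to 60%.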

Compound 4, a percentage reported as activity, at one concentration (the size of the read-out at that concentration, not a potency): 72.1%
For compound 4 the middle estimate is 37.1 percentage points below the measured one; the whole stated range lies below it.
By their numbers in this assay, from the lowest: compounds 2 and 1 (each within the scatter of the next); then compounds 4 and 3 (each within the scatter of the next).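

In this assay, among these compounds, the 2-hydroxyphenyl proves not to be the only group at this saturated ring carbon that gives a high read-out: a number 7.8 percentage points lower from compound 3 to compound 4 (within the scatter), so 4-(dimethylamino)phenyl cannot be told apart from it, although it has no hydrogen-bond donor. The group on the aromatic carbon clearly matters, since dimethylamino gives a number 42.1 percentage points higher from compound 2 to compound 4 (beyond the scatter) and a number 35.5 percentage points higher from compound 1 to compound 4 (beyond the scatter), whereas methyl in compound 2 does not separate from hydrogen in compound 1. No available evidence explains why the 2-hydroxyphenyl and the 4-(dimethylamino)phenyl give such similar read-outs.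

The compounds shown leave open whether a plain amine, a methoxy or a carboxylic acid in place of the dimethylamino would give a similar read-out. As every number comes from a single concentration, they also leave open how compound 3 and compound 4 compare at any other concentration.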